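Swapping Methyl for Iodo on the Sulfonyl Aryl Ring

The compounds below may be only part of what the source reports. "The series", "measured", "known", "first", "only" and "open" are said of these compounds alone.

Of the compounds shown here, two sharing one core have been tested in a functional assay on SGC-7901 cells (Homo sapiens) for antiproliferative activity, read by MTT assay, with a stated time of 48 h; a higher number here means that more compound is needed for the effect, a lower number that less compound is needed. Compound 1, `CC1=NN(C(=O)CBr)C(c2ccccc2O)C1`, gives 4180 nM. Compound 2, `CC1=NN(S(=O)(=O)c2ccccc2C)C(c2cc(Br)ccc2O)C1`, gives 48100 nM, the higher of the two numbers; its distance from compound 1 is beyond the usual scatter, so compound 2 needs clearly more material for the same effect.

The next compound, compound 3, `CC1=NN(S(=O)(=O)c2ccccc2I)C(c2cc(Br)ccc2O)C1`, is not yet measured. It differs from compound 2 in one place: iodo in place of methyl on an aromatic carbon. Cut one bond further out, the change reads 2-methylphenyl to 2-iodophenyl, and the exchanged group sits ortho to a large group on a six-membered aromatic ring of carbon only.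

Among the compounds with values here, no comparable step between measured compounds is at hand, so there is nothing in the data to anchor a direction. The expectation for this assay is therefore a step from compound 2 to compound 3 of roughly a 1.2-fold lower number from compound 2 to compound 3 (0.08 log units; within the scatter), that is, none beyond the scatter. Compound 3 is accordingly estimated at 40000 nM, with a range from 15000 nM to 110000 nM.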

Compound 3, half-maximal effective concentration: > 60000 nM
Compound 3: only a limit was reported; the forecaster's own chance of this, stated with the estimate: 15%; middle value at least 1.5-fold (0.17 log units) away from the limit.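

In this assay, compound 3 reaches only a limit, > 60000 nM, and this is a limit of the assay rather than a true number. This gives the only comparison shown here between two compounds that differ in one place, and with iodo in place of methyl on the aromatic carbon, the step can be read only as a floor: an at least 1.2-fold higher number from compound 2 to compound 3 (0.09 log units; that floor lies within the scatter). The result therefore gives no sign that iodo at this position lowers the number, but the true size of the step stays hidden, and the reading is bounded by one fact: the limit of > 60000 nM in this assay, at which 1 of the 3 values shown sits.

Going by these compounds, it remains open whether the 2-iodophenyl group truly differs from the 2-methylphenyl group in this assay or whether the two simply fall within normal scatter of each other, and a step that ends in a limit cannot settle this. Also open, on these data alone, is how another group at the same place, such as an amine or a carboxylic acid, would compare, and compound 1 cannot help, as it differs from compound 2 in more than one place.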